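Thiazol-5-yl in Place of Cyanophenyl on the Sulfone

The compounds below may be only part of what the source reports. "The series", "measured", "known", "first", "only" and "open" are said of these compounds alone.

Compound 1 `CC(O)(C(=O)Nc1ccc(S(=O)(=O)c2ccc(C#N)cc2)cc1)C(F)(F)F` is the starting point of this account. In a functional assay (Cavia porcellus) with sulfonylurea receptors; K-ATP channels (Homo sapiens) as the target (a lower number here means a stronger inhibitor, a higher number a weaker inhibitor), compound 1 gives > 30000 nM, which is a limit of the measurement rather than a number. The evidence on where compound 1 stands is the limit of > 30000 nM in this assay, at which 1 of the 2 values shown sits. For the measured compounds named here, compound 2 `CC(O)(C(=O)Nc1ccc(S(=O)(=O)c2ccccc2)c(O)c1)C(F)(F)F` belongs to the same set, and in this assay compound 2 gives 430 nM; as compound 2 differs from compound 1 in more than one place, the two values show only that compound 2 yields a number where compound 1 does not. Compound 3 `CC(O)(C(=O)Nc1ccc(S(=O)(=O)c2cncs2)cc1)C(F)(F)F` has not been measured, and it differs from compound 1 by 1,3-thiazol-5-yl in place of 4-cyanophenyl on a sulfonyl sulfur. Going by the values given here, with no measured step of this kind to draw on, the expected step of an at least 1.2-fold lower number from compound 1 to compound 3 (0.07 log units; that floor lies within the scatter) in this assay is small, if any, beyond the scatter, and a limit again seems likely. Compound 3 is expected to give 25000 nM in this assay, within 5000 nM to 100000 nM.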

Compound 3, half-maximal inhibitory concentration: 7700 nM
Beside the measured number, compound 3's estimate is 3.2-fold (0.51 log units) above it; the measured number falls inside the stated range.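

At the sulfonyl sulfur, whose other neighbour is an aromatic carbon, the 4-cyanophenyl group can be exchanged with a gain: in this assay, 1,3-thiazol-5-yl in its place gives an at least 3.8-fold lower number from compound 1 to compound 3 (0.59 log units; beyond the scatter). This is the one change in a single place shown here, and it links a readable number directly to the limit of compound 1, whereas compound 2 differs from compound 1 in more than one place. The true size of the step stays unknown because the value of compound 1 is a limit and not a number: the limit of > 30000 nM in this assay, at which 1 of the 3 values shown sits.

Going by these compounds, whether the gain comes from the thiazole ring itself or simply from the loss of the 4-cyanophenyl group remains open. Also open, on these data alone, is how a pyridine ring or a methyl-bearing thiazole on the sulfonyl sulfur would read in this assay.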